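The source may report more compounds than this note shows. Statements on the series, on what has been measured and on what is new or still open speak of the compounds shown alone.

Compound 1 `Cc1ccc(NC2=CC(=O)c3nc4n(c3C2=O)[C@H]2OC[C@@H](O)[C@H]2OC4)cc1C`: 2820 nM
Compound 2 `CCOc1ccc(NC2=CC(=O)c3c(nc4n3[C@H]3OC[C@@H](O)[C@H]3OC4)C2=O)cc1`: > 4000 nM

Among the measured compounds shown here, in a functional assay on ECa-109 cells for inhibition, with ECa-109 cell line (Homo sapiens) as the target, read by sulforhodamine B assay (on this read-out higher numbers stand for weaker inhibition and lower numbers for stronger inhibition), compound 1 gives 2820 nM, the only actual number among the two values shown. Compound 2 reaches only the limit of the assay, reported as > 4000 nM, a limit and not a number; that is the limit of > 4000 nM in this assay, at which 1 of the 2 values shown sits. Compound 3 `O=C1C=C(Nc2ccc(C(F)(F)F)cc2)C(=O)c2c1nc1n2[C@H]2OC[C@@H](O)[C@H]2OC1` differs from compound 1 by 4-(trifluoromethyl)phenyl in place of 3,4-dimethylphenyl on an amine nitrogen. For the measured compounds named here, no measured step covers such a change, so the step from compound 1 to compound 3 is expected to stay within the scatter or lean slightly toward weaker inhibition, as a 1.2-fold higher number from compound 1 to compound 3 (0.09 log units; within the scatter). Compound 3 is therefore estimated at 3500 nM, with a range from 1500 nM to 9000 nM.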

Compound 3, half-maximal inhibitory concentration: 5500 nM
Compound 3: middle estimate off by 1.6-fold (0.20 log units), on the low side, within the range that was stated.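

Among the compounds shown here, on the amine nitrogen, 4-(trifluoromethyl)phenyl in place of 3,4-dimethylphenyl gives a 2.0-fold higher number from compound 1 to compound 3 (0.29 log units; within the scatter) in this assay, the only measured step at this place. The two groups are therefore not told apart by this read-out, and the place accepts either without a change beyond the scatter. Compound 2 stays a limit and not a number: the limit of > 4000 nM in this assay, at which 1 of the 3 values shown sits.

The compounds shown leave open whether any group at this place can produce a step beyond the scatter. A carboxylic acid or an amine on the phenyl ring, or a plain alkyl chain in place of the ring, could settle that.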